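The compounds below may be only part of what the source reports. "The series", "measured", "known", "first", "only" and "open" are said of these compounds alone.

Measured in a functional assay on T47D cells (Homo sapiens) for antiproliferative activity, read by MTT assay, with a stated time of 72 h; a higher number here means a weaker inhibitor, a lower number a stronger inhibitor:
- Compound 1 `O=C(Nc1ccc(Cl)c(-c2nnc3c(Cl)cccn23)c1)c1ccc(C(F)(F)F)cc1Cl`: > 100000 nM
- Compound 2 `O=C(Nc1ccc(Cl)c(-c2nnc3c(Cl)cccn23)c1)c1cccc(Cl)c1`: 30200 nM

Compound 1 is recorded at > 100000 nM, which is a limit of the assay and not a number. Among the measured compounds shown here, that leaves compound 2, at 30200 nM, as the only true number in this assay, so the series has a single numerical anchor.

The next compound is compound 3 `O=C(Nc1ccc(Cl)c(-c2nnc3c(Cl)cccn23)c1)c1c(F)cccc1Cl`, which carries 2-chloro-6-fluorophenyl in place of 3-chlorophenyl on a carbonyl carbon. For the measured compounds named here, no measured pair shows what such a swap does. The expectation therefore rests on compound 2 at 30200 nM, with no change beyond the usual scatter foreseen. The expected step, a 1.2-fold higher number from compound 2 to compound 3 (0.06 log units; within the scatter), is correspondingly small. For compound 3 the estimate is 35000 nM, with an expected range from 11000 nM to 100000 nM.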

Compound 3, half-maximal inhibitory concentration: > 100000 nM
Compound 3: a limit, no number; the forecaster's own chance of this, stated with the estimate: 30%; at least 2.8-fold (0.45 log units) between middle value and limit.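

In this assay, among the compounds shown here, 2-chloro-6-fluorophenyl in place of 3-chlorophenyl on the carbonyl carbon gives an at least 3.3-fold higher number from compound 2 to compound 3 (0.51 log units; beyond the scatter), the first step that can be read at this position. It shows that this change moves the number beyond the usual scatter, in the direction of a weaker inhibitor. Compound 3 gives > 100000 nM, which is a limit of the assay and not a number, and the full size of the step cannot be told because the reading stops there: the limit of > 100000 nM in this assay, at which 2 of the 3 values shown sit.

The compounds shown leave open whether the chlorine or the fluorine of the entering group matters more, since neither appears alone on a phenyl ring at this place. Also open, going by these compounds, is what an amine or a carboxylic acid on that phenyl ring would do in this assay.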